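A few compounds are considered here, and "the series" means these few. Any claim that something is new, unique, unknown or untested is made for them only; others in the source may bear on it.

Working notes on the series.

Of the compounds shown here, two have numbers so far. Compound 1 `N[C@@H](CSC(Cl)=C(Cl)Cl)C(=O)N[C@@H]1[C@@H](O)[C@H](O)[C@@H](CO)O[C@H]1SC1CCCCC1` gives, in a functional assay on HL-60 cells (Homo sapiens) for cytotoxicity, read by MTT assay, with a stated time of 48 h (on this read-out higher numbers stand for weaker inhibition and lower numbers for stronger inhibition), a value of 112000 nM. Compound 2 `CC(C)(C)OC(=O)N[C@@H](CSC(Cl)=C(Cl)Cl)C(=O)N[C@@H]1[C@@H](O)[C@H](O)[C@@H](CO)O[C@@H]1SC1CCCCC1` gives in this assay a value of 60000 nM. Compound 2 has the lower of the two numbers, but compound 1 sits within the usual scatter of it, so no order between the two can be read from these data; both sit at the weak end of the read-out. For the measured compounds named here, compound 1 and compound 2 differ in more than one place, so no single step between them is drawn.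

The step now followed goes from compound 2 to compound 3 `N[C@@H](CSC(Cl)=C(Cl)Cl)C(=O)N[C@@H]1[C@@H](O)[C@H](O)[C@@H](CO)O[C@@H]1SC1CCCCC1`, which differs from compound 2 only as follows: hydrogen in place of tert-butoxycarbonyl on an amine nitrogen. Compound 3 shares its free amine with compound 1 and its configuration at the sugar with compound 2.

Going by the values given here, no measured step of this kind is available, so the size of the change in this assay is uncertain. Given that compound 1, which also carries the free amine, gives 112000 nM, a step at most of the order of the scatter, towards a higher number, is expected a 1.7-fold higher number from compound 2 to compound 3 (0.22 log units; within the scatter). For compound 3 a value of about 100000 nM is estimated, with a range from 40000 nM to 250000 nM.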

Compound 3, half-maximal inhibitory concentration: 76000 nM
Beside the measured number, compound 3's estimate is 1.3-fold (0.12 log units) above it, within the range that was stated.
By their numbers in this assay, from the lowest: compounds 2, 3 and 1 (each within the scatter of the next).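

In this assay, the tert-butoxycarbonyl group on the amine nitrogen can now be read as a single change, and the step is a 1.3-fold higher number from compound 2 to compound 3 (0.10 log units; within the scatter); at this position, in this configuration, the values with tert-butoxycarbonyl and with hydrogen cannot be told apart. For the compounds shown here, the configuration at the saturated ring carbon can also be read alone for the first time, and the step is a 1.5-fold lower number from compound 1 to compound 3 (0.17 log units; within the scatter), so this change does not separate the two compounds in this assay either. This second comparison isolates that one stereocentre, with no other structural change involved: the fact that compounds 1 and 3 differ only in the configuration as drawn

On these data alone, it remains open whether an acetyl group or a longer acyl chain on this amine nitrogen would give a value beyond the scatter of those seen so far. As far as these compounds go, it also remains open whether the two configurations at the ring carbon would stay within the scatter of each other with tert-butoxycarbonyl on the nitrogen.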